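Side-chain variation on the amino-acid carbon: compound 4

This account rests on a few compounds, and the source may have more. Where it says the series, first, only, none or still open, it means among the compounds named here.

Measured compounds:
Compound 1 `O=C(CN(c1ncnc2c1ncn2C1CCCCO1)C1CC1)N[C@@H](CO)C(=O)OCc1ccccc1`; in a functional assay on the whole organism (Tail, strain ICR) with Mus musculus as the target, in the tail flick test, with a stated time of 150 min, at a dose of 25 umol/kg by the oral route (a higher number here means a stronger effect of the compound at the dose given, a lower number a weaker effect), compound 1 gives 18.3%.
Compound 2 `CC(C)[C@H](NC(=O)CN(c1ncnc2c1ncn2C1CCCCO1)C1CC1)C(=O)OCc1ccccc1`; compound 2 gives 21.1%.
Compound 3 `CC[C@H](C)[C@H](NC(=O)CN(c1ncnc2c1ncn2C1CCCCO1)C1CC1)C(=O)OCc1ccccc1`; compound 3 gives 16.4%.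

Compound 3 is not separated from either neighbour: a number 1.9 percentage points lower from compound 1 to compound 3 (within the scatter) and a number 4.7 percentage points lower from compound 2 to compound 3 (within the scatter). Likewise a number 2.8 percentage points higher from compound 1 to compound 2 (within the scatter). All three side chains on the saturated chain carbon bound to an amide-type nitrogen and a carbonyl carbon therefore give one undifferentiated level in this assay.

Compound 4 `CSCC[C@H](NC(=O)CN(c1ncnc2c1ncn2C1CCCCO1)C1CC1)C(=O)OCc1ccccc1` carries 2-(methylsulfanyl)ethyl in place of sec-butyl on a saturated chain carbon bound to an amide-type nitrogen and a carbonyl carbon. Within the data shown here, the steps that bear on this change are those at the same place, from compound 1 and from compound 2 to compound 3, both within the scatter; no measured step exchanges a carbon chain for one holding a sulfur, so that part of the change is unsupported by the data. With nothing pointing either way, no step beyond the scatter is expected, a number 1.6 percentage points higher from compound 3 to compound 4 (within the scatter). Compound 4 is estimated at 18%, with a range from 8% to 30%.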

Compound 4, a percentage reported as activity, at one dose (the size of the read-out at that dose, not a potency): 17.5%
The estimate for compound 4 lay 0.5 percentage points above the measured number; low and high end bracket the measured number.
By their numbers in this assay, from the lowest: compounds 3, 4, 1 and 2 (each within the scatter of the next).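

In this assay, the 2-(methylsulfanyl)ethyl side chain, the first here to hold a sulfur, stays on the level already set by the hydroxymethyl, isopropyl and sec-butyl side chains: a number 1.1 percentage points higher from compound 3 to compound 4 (within the scatter), a number 3.6 percentage points lower from compound 2 to compound 4 (within the scatter) and a number 0.8 percentage points lower from compound 1 to compound 4 (within the scatter). Exchanging a carbon for a sulfur and bringing in a hydrogen-bond acceptor on the saturated chain carbon bound to an amide-type nitrogen and a carbonyl carbon therefore leaves the read-out undifferentiated across all four compounds. No supporting data offer an explanation for this result.

Going by these compounds, whether an amine, a carboxylic acid or a longer chain at this place would leave that level remains open. The read-out also comes from one dose and one time, so any potency differences among these side chains stay unresolved.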